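A larger group on the aromatic nitrogen of compound 4

The compounds below may be only part of what the source reports. "The series", "measured", "known", "first", "only" and "open" are said of these compounds alone.

Of the compounds shown here, three that share one core have been tested in an ADME assay on cells (Hepatocyte, Rattus norvegicus) for metabolic stability; on this read-out higher numbers stand for fast clearance and lower numbers for slow clearance. Compound 1 `CC(=O)N1CCC(c2cc3c(-c4ccc(=O)n(C(C)C)c4)ccnc3[nH]2)CC1` gives 2.8 uL/min. Compound 2 `CC(C)n1cc(-c2ccnc3[nH]c(C4CCN(CC(=O)N5CCCCC5)CC4)cc23)ccc1=O` gives 26 uL/min, and compound 3 `CC(C)n1cc(-c2ccnc3[nH]c(C4CCN(CC(=O)N(C)C)CC4)cc23)ccc1=O` gives 2.3 uL/min. Among these three numbers compound 3 stands lowest. Compound 1 lies nearest to it, and a 1.2-fold lower number from compound 1 to compound 3 (0.09 log units; within the scatter) is within the scatter, so the two cannot be told apart. Compound 2 lies furthest away: an 11-fold lower number from compound 2 to compound 3 (1.05 log units; beyond the scatter) and a 9.3-fold higher number from compound 1 to compound 2 (0.97 log units; beyond the scatter) are both beyond the scatter. Every one of these steps concerns the group on the amine nitrogen in the ring or on the carbonyl carbon.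

Compound 4 `CN(C)C(=O)CN1CCC(c2cc3c(-c4ccc(=O)n(CC5CCOCC5)c4)ccnc3[nH]2)CC1` has not yet been measured. It differs from compound 3 in a different place: (oxan-4-yl)methyl in place of isopropyl on an aromatic nitrogen. Within the data shown here, none of the measured steps touches the group on the aromatic nitrogen, since all three measured compounds carry isopropyl there, so the measured record gives no direct guide to this change. The amide side of compound 4 is exactly that of compound 3. The estimate for compound 4 in this assay is therefore 3.5 uL/min, with a range from 1.5 uL/min to 9 uL/min. The expected step of a 1.5-fold higher number from compound 3 to compound 4 (0.18 log units; within the scatter) is not expected to go beyond the scatter in either direction.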

Compound 4, intrinsic clearance in a liver preparation (reported as CLH), per the amount of preparation that the assay uses: 1.8 uL/min
Compound 4: the middle estimate sits 1.9-fold (0.29 log units) above what was measured; measured number inside the range.
By their numbers in this assay, from the lowest: compounds 4, 3 and 1 (each within the scatter of the next); then compound 2.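

In this assay, among these compounds, the earlier compounds all carry isopropyl on the aromatic nitrogen, so they say nothing about this position; the change to (oxan-4-yl)methyl gives a 1.3-fold lower number from compound 3 to compound 4 (0.11 log units; within the scatter), and the two compounds cannot be told apart. The group here grows from 3 heavy atoms to 7 and gains a six-membered non-aromatic ring and a hydrogen-bond acceptor, yet the read-out shows no change beyond the scatter, whereas the swap between piperidin-1-yl and dimethylamino on the carbonyl carbon gives an 11-fold lower number from compound 2 to compound 3 (1.05 log units; beyond the scatter). No measurement shown here explains why this larger group leaves the clearance within the scatter.

Going by these compounds, this position is tested by a single pair, with the dimethylamino amide of compound 3 on the other side of the molecule, so it remains open whether the same swap would also stay within the scatter with the piperidin-1-yl amide of compound 2. On these data alone, it also remains open how other groups on the aromatic nitrogen, such as methyl, a longer chain or a chain ending in an amine or a carboxylic acid, would behave in this assay.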